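Hydroxamic acid series: aryl group on the triazole nitrogen

A few compounds are considered here, and "the series" means these few. Any claim that something is new, unique, unknown or untested is made for them only; others in the source may bear on it.

Measured so far:
compound 1 `O=C(NO)c1ccc(NCc2nc(-c3ccccc3)nn2-c2ccc(Br)cc2)cc1` – 65.9%
compound 2 `O=C(NO)c1ccc(NCc2nc(-c3ccccc3)nn2-c2ccc(C(F)(F)F)cc2)cc1` – 38.9%

Both compounds were tested in an assay on Sf9 cells for inhibition of protein deacetylase HDAC6 (Homo sapiens), read by fluorescence, with a stated time of 40 min, tested at 100 nM; a lower number here means less inhibition, a higher number more inhibition at the concentration tested (going by the name of the read-out). Compound 1 gives 65.9% and compound 2 gives 38.9%, so compound 2 holds the lowest of the two numbers recorded, and its nearest neighbour is compound 1. Among the compounds with values here, the only step between measured compounds is a number 27 percentage points lower from compound 1 to compound 2 (beyond the scatter), a modest change that lies beyond the scatter, and it concerns the same aromatic nitrogen substituent that is varied next.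

Compound 3 `Cc1ccc(-n2nc(-c3ccccc3)nc2CNc2ccc(C(=O)NO)cc2)cc1C` is not yet measured. It differs from compound 2 in one place: 3,4-dimethylphenyl in place of 4-(trifluoromethyl)phenyl on an aromatic nitrogen. Within the data shown here, the step from compound 1 to compound 2 bears on this change only in showing that the group on this aromatic nitrogen can shift the read-out by a modest amount; no measured pair involves a methylated aryl group, so the direction is not fixed by the data. Compound 3 is therefore expected to lie between the two recorded numbers, as a step of a number 11.1 percentage points higher from compound 2 to compound 3 (beyond the scatter). The estimate for compound 3 is 50%, with a range from 30% to 72%.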

Compound 3, a percentage reported as inhibition, at one concentration (the size of the read-out at that concentration, not a potency): 53%
Compound 3: middle estimate off by 3 percentage points, on the low side; the range from low to high includes it.
By their numbers in this assay, from the lowest: compound 2; then compound 3; then compound 1.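

In this assay, the 3,4-dimethylphenyl group adds a third point at this aromatic nitrogen and shows that the read-out is not confined to the two earlier values: a number 14.1 percentage points higher from compound 2 to compound 3 (beyond the scatter), while a number 12.9 percentage points lower from compound 1 to compound 3 (beyond the scatter). All three aryl groups are now separated beyond the scatter, in the order 4-(trifluoromethyl)phenyl, then 3,4-dimethylphenyl, then 4-bromophenyl, so a phenyl ring with two carbon substituents keeps more of the read-out than the 4-(trifluoromethyl)phenyl group but less than the 4-bromophenyl group, and this order holds for these three compounds only. Nothing available explains this order, and the gain from compound 2 to compound 3 cannot be assigned to the loss of trifluoromethyl or to either methyl group.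

Open questions remain about how an unsubstituted phenyl, a 4-methylphenyl, a 4-methoxyphenyl or a 4-aminophenyl group on this aromatic nitrogen would place relative to these three, which would show whether one methyl group carries the step and whether a group holding oxygen or nitrogen fits the order. The figures also come from one concentration, so they leave the potency of all three compounds open.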